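Indol-3-yl in place of phenyl on the carbonyl of compound 1

The source may hold more compounds than are shown below. What is called first, only, known or untested is meant among the compounds shown, and "the series" means these compounds.

Among the measured compounds shown here, compound 1 `COc1ccc(-c2cc3ccccc3nc2/C=C/C(=O)c2ccccc2)cc1` is the only member of the series with a number in a functional assay on H184B5F5/M10 cells (Homo sapiens) for antiproliferative activity, read by XTT assay, with a stated time of 72 h; a lower number here means a stronger inhibitor, a higher number a weaker inhibitor; here compound 1 gives 8560 nM. Compound 2 `COc1ccc(-c2cc3ccccc3nc2/C=C/C(=O)c2ccc(F)cc2)cc1` is reported in this assay only as a limit, > 10000 nM. Compound 3 `COc1ccc(-c2cc3ccccc3nc2/C=C/C(=O)c2cnc(N)nc2C)cc1` likewise stands at a limit, > 10000 nM. Two of the three values shown thus sit at the limit of > 10000 nM in this assay, at which 2 of the 3 values shown sit.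

Both measured steps start from compound 1 and point the same way: an at least 1.1-fold higher number from compound 1 to compound 2 (0.06 log units; that floor lies within the scatter) with fluoro in place of hydrogen on an aromatic carbon, and an at least 1.1-fold higher number from compound 1 to compound 3 (0.06 log units; that floor lies within the scatter) with 2-amino-4-methylpyrimidin-5-yl in place of phenyl on a carbonyl carbon. Between compound 2 and compound 3 the step is a step that the two limits leave unreadable from compound 2 to compound 3.

Compound 4 `COc1ccc(-c2cc3ccccc3nc2/C=C/C(=O)c2c[nH]c3ccccc23)cc1` differs from compound 1 by 1H-indol-3-yl in place of phenyl on a carbonyl carbon. The step to compound 3 bears most directly on it, as both exchange the phenyl on the carbonyl carbon for a heteroaromatic group, and it reads only as a floor toward a higher number. Compound 4 is therefore expected to show a step of a 1.1-fold higher number from compound 1 to compound 4 (0.02 log units; within the scatter), small or none beyond the scatter. Compound 4 is estimated at 9000 nM. The expected range for compound 4 runs from 3000 nM to 25000 nM, with a real chance that only a limit is reported.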

Compound 4, half-maximal inhibitory concentration: > 10000 nM
Compound 4 was reported as a limit; the forecaster's own chance of this, stated with the estimate: 45%; middle value at least 1.1-fold (0.04 log units) away from the limit.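

In this assay, 1H-indol-3-yl in place of phenyl on the carbonyl carbon gives an at least 1.1-fold higher number from compound 1 to compound 4 (0.06 log units; that floor lies within the scatter), and that floor does not establish a real change. The value of compound 4 is a limit, so a group with a five-membered aromatic ring joins 4-fluorophenyl and 2-amino-4-methylpyrimidin-5-yl among the replacements at this position that yield no number. The steps among compound 2, compound 3 and compound 4 cannot be read, and compound 1 remains the only compound with a number: the limit of > 10000 nM in this assay, at which 3 of the 4 values shown sit.

The compounds shown leave open whether any group on this carbonyl carbon gives a lower number than compound 1, for instance a morpholine or a methyl in place of phenyl. They also leave open how changes elsewhere on the shared core would read in this assay.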